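This account rests on a few compounds, and the source may have more. Where it says the series, first, only, none or still open, it means among the compounds named here.

Compound 1 `Cc1noc(C)c1-c1cnc(N)c(Oc2ccc(C(=O)NC3CCCC3)cc2)n1` gives 12800 nM in a functional assay on HepG2 cells (Homo sapiens) for inhibition, read by MTT assay, with a stated time of 72 h; a lower number here means a stronger inhibitor, a higher number a weaker inhibitor.
Compound 2 `Cc1noc(C)c1-c1cnc(N)c(Oc2ccc(C(=O)NC3CCCCC3)cc2)n1` gives 5420 nM.
Compound 3 `Cc1noc(C)c1-c1cnc(N)c(Oc2ccc(C(=O)Nc3ccccc3Cl)cc2)n1` gives > 100000 nM, a limit of the assay rather than a number.

Compound 3 thus sits at the limit of > 100000 nM in this assay, at which 1 of the 3 values shown sits, and is the weakest of the three. The measured steps go in one direction: a 2.4-fold lower number from compound 1 to compound 2 (0.37 log units; beyond the scatter) is modest, whereas an at least 7.8-fold higher number from compound 1 to compound 3 (0.89 log units; beyond the scatter) and an at least 18-fold higher number from compound 2 to compound 3 (1.26 log units; beyond the scatter) both move sharply toward weaker inhibition when an aromatic group replaces a cycloalkyl group on the amide nitrogen. Compound 4 `Cc1noc(C)c1-c1cnc(N)c(Oc2ccc(C(=O)Nc3cccc(Cl)c3)cc2)n1` differs from compound 3 by 3-chlorophenyl in place of 2-chlorophenyl on an amide-type nitrogen. Among the measured compounds shown here, no measured step moves the chlorine around the phenyl ring, so this change has no direct precedent here. Compound 4 is expected to remain weak, since the aryl amide of compound 3 reached the limit. Compound 4 is estimated at 60000 nM with a range of 15000 nM to 200000 nM; the expected step is an at least 1.6-fold lower number from compound 3 to compound 4 (0.22 log units; that floor lies within the scatter).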

Compound 4, half-maximal inhibitory concentration: 7300 nM
The estimate for compound 4 lay 8.2-fold (0.91 log units) above the measured number, outside the stated range (below it).
By their numbers in this assay, from the lowest: compounds 2, 4 and 1 (each within the scatter of the next, the first and the last beyond it). At a limit, above all of these: compound 3.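

In this assay, moving the chlorine on the amide-type nitrogen's aryl group from 2-chlorophenyl to 3-chlorophenyl gives an at least 13-fold lower number from compound 3 to compound 4 (1.13 log units; beyond the scatter), so among these compounds an aryl group at this position does not by itself mean weak inhibition. The 3-chlorophenyl amide also reads level with both cycloalkyl amides, with a 1.3-fold higher number from compound 2 to compound 4 (0.13 log units; within the scatter) and a 1.8-fold lower number from compound 1 to compound 4 (0.24 log units; within the scatter). Compound 3 remains a limit of the assay rather than a number: the limit of > 100000 nM in this assay, at which 1 of the 4 values shown sits.

The compounds shown leave open how a phenyl group without chlorine would read here. They also leave open whether bromine or a methoxy group in place of the chlorine would show the same dependence on position.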